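Swapping an aryl amide for a piperidinylmethyl amide in a pyrazoline series

The source may hold more compounds than are shown below. What is called first, only, known or untested is meant among the compounds shown, and "the series" means these compounds.

Three pyrazolines have been examined in a functional assay on HepG2 cells (Homo sapiens) for cytotoxicity, read by MTT assay, with a stated time of 48 h; a higher number here means a weaker inhibitor, a lower number a stronger inhibitor. Compound 1 `CC1=NN(C(=O)c2ccc(C)cc2)C(c2cc(Br)ccc2O)C1` gives 23200 nM, while compound 2 `CC1=NN(S(=O)(=O)c2ccc([N+](=O)[O-])cc2)C(c2cc(Br)cc(Br)c2O)C1` is recorded as "not active" (no number reported) with no single number. Compound 3 `Cc1ccc(C(=O)N2N=C(c3cc4ccccc4oc3=O)CC2c2ccccc2)cc1` gives 52300 nM in this assay, the higher of the two numbers, standing beyond the scatter from compound 1. The next step leads to compound 4 `CC1CCCN(CC(=O)N2N=C(c3cc4ccccc4oc3=O)CC2c2ccccc2)C1`, which differs from compound 3 by (3-methylpiperidin-1-yl)methyl in place of 4-methylphenyl on a carbonyl carbon on the carbonyl carbon of the shared core. Going by the values given here, no comparable step has been measured here, so for compound 4 only a modest shift in this assay is expected, in either direction and possibly none beyond the scatter, as a 1.0-fold lower number from compound 3 to compound 4 (0.02 log units; within the scatter). Compound 4 is therefore estimated at 50000 nM, within a range of 20000 nM to 120000 nM.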

Compound 4, half-maximal inhibitory concentration: "not active" (no number reported)
Compound 4: no number reported; the estimate stays without a comparison.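

In this assay, going by these compounds alone, compound 4 gives "not active" (no number reported), so no step from compound 3 can be read. The compounds shown leave open how far (3-methylpiperidin-1-yl)methyl in place of 4-methylphenyl shifts the number. No evidence bears on this result.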